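Dimethylamino in Place of Imidazolyl on Two Alkyne Cores

A few compounds are considered here, and "the series" means these few. Any claim that something is new, unique, unknown or untested is made for them only; others in the source may bear on it.

Compound 1, `CC(C#CCn1ccnc1)N1CCCC1=O`, gives a limit, > 100 mg/kg.
Compound 2, `CC(C#CCN(C)C)N1CCCC1=O`, gives 6.6 mg/kg.
Compound 3, `COC(=O)N(C)CC#CCn1ccnc1`, gives 4.5 mg/kg.

In a functional assay on the whole organism for agonist activity, with Mus musculus as the target (a lower number here means that less compound is needed, a higher number that more compound is needed for the effect), the reading for compound 1 is only a limit of the assay, not a number (the limit of > 100 mg/kg in this assay, at which 1 of the 3 values shown sits). The change dimethylamino in place of 1H-imidazol-1-yl on a saturated chain carbon bound to a triple-bonded carbon brings an at least 15-fold lower number from compound 1 to compound 2 (1.18 log units; beyond the scatter). The core of compound 3 differs from the core of compound 1, but that difference is not broken down here. Compound 4, `COC(=O)N(C)CC#CCN(C)C`, carries the same change as compound 2: dimethylamino in place of 1H-imidazol-1-yl on a saturated chain carbon bound to a triple-bonded carbon. Within the data shown here, because compound 3 already gives 4.5 mg/kg, the step is expected to be smaller than the one from compound 1 to compound 2. A step of a 2.3-fold lower number from compound 3 to compound 4 (0.35 log units; beyond the scatter) is estimated. Compound 4 is expected to give 2 mg/kg, within 0.6 mg/kg to 6 mg/kg.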

Compound 4, dose for half-maximal effect: 14.3 mg/kg
For compound 4 the middle estimate is 7.2-fold (0.85 log units) below the measured one, outside the stated range (above it).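

In this assay, dimethylamino in place of 1H-imidazol-1-yl brings a 3.2-fold higher number from compound 3 to compound 4 (0.50 log units; beyond the scatter), so the change does not carry from one core to the other with the same direction or size: the same change on two cores in this assay, an at least 15-fold lower number (1.18 log units; beyond the scatter) from compound 1 to compound 2 and a 3.2-fold higher number (0.50 log units; beyond the scatter) from compound 3 to compound 4, at least 48-fold (1.68 log units) apart, beyond the scatter of two such steps. The reading for compound 1 is a limit of the assay and not a number, so the earlier step is known only as a bound: the limit of > 100 mg/kg in this assay, at which 1 of the 4 values shown sits. The two cores show that the result of this change differs with the core, but not which part of the core matters or why.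

Going by these compounds, it remains open whether diethylamino on a saturated chain carbon bound to a triple-bonded carbon would follow compound 2 or compound 4. On these data alone, it is also open how either step would look on a core with a longer chain.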